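This account rests on a few compounds, and the source may have more. Where it says the series, first, only, none or still open, it means among the compounds named here.

Compound 1, with the structure `COc1ccc(Cn2nc(-c3ccccc3)c3cc(C(=N)Nc4ccccc4)nc(NC4CCCCC4)c32)cc1`, is the starting point. In a functional assay on PC-3 cells (Homo sapiens) for cytotoxicity, read by MTT assay, with a stated time of 72 h (a higher number here means a weaker inhibitor, a lower number a stronger inhibitor), compound 1 gives 1100 nM. Compound 3, `COc1ccc(Cn2nc(-c3ccccc3)c3cc(C(=N)Nc4ccc(N5CCN(C)CC5)cc4)nc(NC4CCCCC4)c32)cc1`, carries one change relative to compound 1, namely (4-methylpiperazin-1-yl in place of hydrogen on an aromatic carbon), and in this assay compound 3 gives 3540 nM; the step is a 3.2-fold higher number from compound 1 to compound 3 (0.51 log units; beyond the scatter).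

Compound 2, `N=C(Nc1ccccc1)c1cc2c(-c3ccccc3)n[nH]c2cn1`, has a smaller core; the difference between the two cores is not broken down here. In this assay compound 2 gives 23000 nM, the highest number among the three measured compounds.

Compound 4, `CN1CCN(c2ccc(NC(=N)c3cc4c(-c5ccccc5)n[nH]c4cn3)cc2)CC1`, is not yet measured. Among the measured compounds shown here, it differs from compound 2 by 4-methylpiperazin-1-yl in place of hydrogen on an aromatic carbon, which is the same change, at the same kind of place, as the one that turned compound 1 into compound 3. The expected step from compound 2 to compound 4 in this assay is a 3.0-fold higher number from compound 2 to compound 4 (0.48 log units; beyond the scatter), set beside the earlier step because a 3.2-fold higher number from compound 1 to compound 3 (0.51 log units; beyond the scatter) is the only direct observation of this change. Compound 4 is therefore estimated to give 70000 nM, with a range from 25000 nM to 200000 nM.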

Compound 4, half-maximal inhibitory concentration: 17100 nM
Compound 4: the middle estimate sits 4.1-fold (0.61 log units) above what was measured; measured number below the stated range.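

On the smaller core, in this assay adding 4-methylpiperazin-1-yl gives a 1.3-fold lower number from compound 2 to compound 4 (0.13 log units; within the scatter) and so shows no readable change in the number. Two pairs of compounds cannot tell why the cores respond differently or how a third core would respond, and they show nothing about what this group does outside this one cell test. They do show that the size of the step seen on the core of compound 1 did not carry over to the smaller core, so a step measured on one core in this series is not a safe guide to the other: the same change on two cores in this assay, a 3.2-fold higher number (0.51 log units; beyond the scatter) from compound 1 to compound 3 and a 1.3-fold lower number (0.13 log units; within the scatter) from compound 2 to compound 4, 4.3-fold (0.64 log units) apart, beyond the scatter of two such steps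

Still open, on these data alone, is how the two cores would respond to other groups at the same place on the aromatic ring, such as a morpholine ring, a simple amine or a carboxylic acid. As far as these compounds go, it also remains open which of the parts separating the two cores matters, and a compound holding only one of those parts would be needed to tell.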